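The source may report more compounds than this note shows. Statements on the series, on what has been measured and on what is new or still open speak of the compounds shown alone.

Measured compounds in a functional assay (aorta) for antagonist activity, with Oryctolagus cuniculus as the target; on this read-out higher numbers stand for weaker inhibition and lower numbers for stronger inhibition:
- compound 1, `CCCCc1ccc(CNC(=O)OC(C)(C)C)c(=O)n1Cc1ccc(-c2ccccc2-c2nn[nH]n2)cc1`, which gives 10 nM
- compound 2, `CCCCc1ccc(CNCc2ccccc2)c(=O)n1Cc1ccc(-c2ccccc2-c2nn[nH]n2)cc1`, which gives 1 nM

Among the compounds with values here, compound 2 stands lowest of the two numbers in this assay, and the only other compound, compound 1, is separated from it by a 10-fold lower number from compound 1 to compound 2 (1.00 log units; beyond the scatter). Compound 3, `CCCCc1ccc(CNC(=O)NC2CCCCC2)c(=O)n1Cc1ccc(-c2ccccc2-c2nn[nH]n2)cc1`, differs from compound 2 in one place: cyclohexylcarbamoyl in place of benzyl on an amine nitrogen. Within the data shown here, the single measured step that bears on this change is a 10-fold lower number from compound 1 to compound 2 (1.00 log units; beyond the scatter), where a tert-butoxycarbonyl gave way to the benzyl that compound 3 now loses. The entering cyclohexylcarbamoyl carries a carbonyl, as the tert-butoxycarbonyl of compound 1 did, so a partial return toward the number of compound 1 is expected rather than a further fall, which is the step of a 5.0-fold higher number from compound 2 to compound 3 (0.70 log units; beyond the scatter). Compound 3 is therefore estimated at 5 nM in this assay, with a range from 1.5 nM to 20 nM.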

Compound 3, half-maximal inhibitory concentration: 90 nM
Compound 3: middle estimate off by 18-fold (1.26 log units), on the low side; measured number outside the range, above it.
By their numbers in this assay, from the lowest: compound 2; then compound 1; then compound 3.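

In this assay the change from benzyl to cyclohexylcarbamoyl on the amine nitrogen gives a 90-fold higher number from compound 2 to compound 3 (1.95 log units; beyond the scatter) and leaves compound 3 last of the three, so this position responds strongly to the group placed there. A carbonyl on that nitrogen does not by itself fix the number: cyclohexylamino in place of tert-butoxy on the carbonyl carbon gives a 9.0-fold higher number from compound 1 to compound 3 (0.95 log units; beyond the scatter) and shows that what the carbonyl carries also matters. Nothing available here explains either step.

The compounds shown do not separate the part played by the carbamoyl link from that of the cyclohexyl ring, a question that phenylcarbamoyl or cyclohexylmethyl on the same nitrogen would address. Also open, from the compounds shown here alone, is how this assay would read acetyl or a free primary amine at this place.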